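The source may hold more compounds than are shown below. What is called first, only, known or untested is meant among the compounds shown, and "the series" means these compounds.

The measured compounds:
Compound 1, `O=C1/C(=C\c2ccc(O)cc2)c2ccccc2N1c1c(Cl)cccc1Cl`, gives 33 ug/mL in a functional assay on B16-F10 cells (Homo sapiens) for cytotoxicity against B16-F10 (Mus musculus), read by MTT assay, with a stated time of 72 h; a higher number here means that more compound is needed for the effect, a lower number that less compound is needed.
Compound 2, `Cc1ccc2nc(Cl)c(/C=C3\C(=O)N(c4c(Cl)cccc4Cl)c4ccccc43)cc2c1C`, reaches only a limit of this assay, > 100 ug/mL.
Compound 3, `O=C1/C(=C\c2ccccc2[N+](=O)[O-])c2ccccc2N1c1c(Cl)cccc1Cl`, likewise reaches only a limit, > 100 ug/mL.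

Compound 1 therefore stands as the only one of the three with an actual number; the other two sit at the limit of > 100 ug/mL in this assay, at which 2 of the 3 values shown sit. Compound 4, `O=C1/C(=C\c2ccc(Cl)cc2)c2ccccc2N1c1c(Cl)cccc1Cl`, has not yet been measured. It differs from compound 1 in one place: chloro in place of hydroxy on an aromatic carbon.

Among the measured compounds shown here, only one measured step touches the same ring: an at least 3.0-fold higher number from compound 1 to compound 3 (0.48 log units; beyond the scatter), where the 4-hydroxyphenyl group was replaced and the effect weakened by at least a modest amount. That replacement exchanged the whole ring substituent, whereas compound 4 exchanges just the hydroxy group for chloro. On that basis the number for compound 4 is expected to rise somewhat above compound 1, an expected step of a 1.7-fold higher number from compound 1 to compound 4 (0.22 log units; within the scatter), with a fair chance that this assay again reports only a limit. The estimate for compound 4 is 55 ug/mL, in a range from 20 ug/mL to 130 ug/mL.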

Compound 4, concentration for half-maximal effect: > 100 ug/mL
Compound 4: a limit, no number; the forecaster's own chance of this, stated with the estimate: 35%; at least 1.8-fold (0.25 log units) between middle value and limit.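

Exchanging one atom on the ring, hydroxy for chloro on the aromatic carbon para to a large group, is enough on its own to give an at least 3.0-fold higher number from compound 1 to compound 4 (0.48 log units; beyond the scatter). The earlier step on this ring, an at least 3.0-fold higher number from compound 1 to compound 3 (0.48 log units; beyond the scatter), exchanged the whole 4-hydroxyphenyl group, so it could not show whether the hydroxy alone mattered; here the rest of the ring stays the same and the number for compound 1 is still lost. The result for compound 4 is a limit and not a number, and the step from compound 3 to compound 4 cannot be read: the limit of > 100 ug/mL in this assay, at which 3 of the 4 values shown sit.

Still open, on these data alone, is how large the step from the hydroxy really is. As far as these compounds go, it is also open whether an amine or a methoxy group in the same place would give a number in this assay like that of compound 1 or would end at a limit too.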